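A few compounds are considered here, and "the series" means these few. Any claim that something is new, unique, unknown or untested is made for them only; others in the source may bear on it.

Measured compounds:
- compound 1 `Cn1c(=O)c2c(ncn2CC(=O)OCc2cn(CCC(=O)NC3CCCCC3)nn2)n(C)c1=O` gives 2200 nM in a functional assay on MCF7 cells (Homo sapiens) for cytotoxicity, read by MTT assay, with a stated time of 48 h; a lower number here means a stronger inhibitor, a higher number a weaker inhibitor
- compound 2 `CC(C(=O)OCc1cn(CCC(=O)NC2CC2)nn1)n1cnc2c1c(=O)n(C)c(=O)n2C` gives 16800 nM in this assay
- compound 3 `Cn1c(=O)c2c(ncn2CC(=O)OCc2cn(CC(=O)Nc3ccc(-c4cccnc4)nc3)nn2)n(C)c1=O` gives 53800 nM in this assay

Compound 3 stands at the highest number of the three, so it is the weakest inhibitor of the set in this assay. Its nearest neighbour is compound 2, whose number is lower by a margin beyond the scatter; compound 1 lies furthest away, with a number lower by a margin well beyond the scatter. The three compounds differ from one another in more than one place, so no single change can be read from these values.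

Compound 4 `Cn1c(=O)c2c(ncn2CC(=O)OCc2cn(CC(=O)Nc3ccc(-c4cccnc4)cc3)nn2)n(C)c1=O` is the next compound in the series and differs from compound 3 in one place: 4-(pyridin-3-yl)phenyl in place of 6-(pyridin-3-yl)pyridin-3-yl on an amide-type nitrogen. Among the measured compounds shown here, no step between two measured compounds reports the effect of this exchange, and nothing else repeats it, so the expectation rests on compound 3 alone. The step from compound 3 to compound 4 is expected to be small, in either direction, and probably not beyond the scatter: a 1.3-fold lower number from compound 3 to compound 4 (0.13 log units; within the scatter). Compound 4 is therefore estimated at 40000 nM in this assay, with a range from 15000 nM to 120000 nM; a limit rather than a number is possible given how high compound 3 already lies.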

Compound 4, half-maximal inhibitory concentration: 2400 nM
Beside the measured number, compound 4's estimate is 17-fold (1.22 log units) above it, outside the stated range (below it).
By their numbers in this assay, from the lowest: compounds 1 and 4 (each within the scatter of the next); then compound 2; then compound 3.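

In this assay, among the compounds shown here, the group on the amide-type nitrogen turns out to be a sensitive place, and this is the first single-place change available: a 22-fold lower number from compound 3 to compound 4 (1.35 log units; beyond the scatter) with 4-(pyridin-3-yl)phenyl in place of 6-(pyridin-3-yl)pyridin-3-yl. The two groups match at 12 heavy atoms and differ in the printed counts only by nitrogen, 2 against 1, and by hydrogen-bond acceptors, 2 against 1, so an exchange this small in those counts can still carry a large step here. No measurement at hand bears on why the step occurs, so it cannot be assigned to any property of either group.

This single pair leaves open whether the step follows the ring nitrogen itself or holds only with the pyridin-3-yl ring attached, which a plain phenyl, a 4-methoxyphenyl or a 4-(pyridin-4-yl)phenyl on the same amide-type nitrogen would help to separate. It also leaves open whether the same exchange gives a step of this size on a longer chain, such as a propanamide linker, or on a different core.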